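A few compounds are considered here, and "the series" means these few. Any claim that something is new, unique, unknown or untested is made for them only; others in the source may bear on it.

Measured so far in a physicochemical assay for lipophilicity, read by HPLC, at pH 7.5; a higher number here means a more lipophilic compound, a lower number a more polar compound:
compound 1 `CC[C@H](Nc1c(C#N)c(-c2ccc(Br)cc2)nc2cnccc12)C(N)=O`: 2.3
compound 2 `CCOc1ccccc1-c1ccc(-c2nc3cnccc3c(N[C@H](CC)C(=O)N(C)C)c2C#N)cc1`: 3.7
compound 3 `CN(CC(N)=O)c1c(C#N)c(-c2ccc(Br)cc2)nc2cnccc12`: 2.1

Compound 2 stands highest of the three in this assay; compound 1 lies nearest, compound 3 furthest, both gaps beyond the scatter. Among the measured compounds shown here, the only measured step, a number 0.20 log units lower from compound 1 to compound 3 (within the scatter), also alters the substituent on the ring nitrogen and stays within the scatter.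

Compound 4 `CCOc1ccccc1-c1ccc(-c2nc3cnccc3c(NC(C(N)=O)C3CC3)c2C#N)cc1` differs from compound 2 at that same position: a group of 7 heavy atoms (5 carbon, 1 nitrogen, 1 oxygen; one three-membered non-aromatic ring of carbon only) in place of a group of 8 heavy atoms (6 carbon, 1 nitrogen, 1 oxygen; no ring), on a nitrogen on an aromatic ring

The measured step gives no lead on exchanging a dimethylcarbamoyl for a carbamoyl with one donor; a downward step in this assay beyond the scatter is expected. The step from compound 2 to compound 4 is estimated as a number 0.60 log units lower from compound 2 to compound 4 (beyond the scatter). For compound 4 the expected value in this assay is 3.1, ranging from 2.6 to 3.6.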

Compound 4, distribution coefficient: 3
The estimate for compound 4 lay 0.10 log units above the measured number; measured number inside the range.
By their numbers in this assay, from the lowest: compounds 3 and 1 (each within the scatter of the next); then compound 4; then compound 2.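

In this assay, the exchange at this place, on a nitrogen on an aromatic ring, gives a number 0.70 log units lower from compound 2 to compound 4 (beyond the scatter), so a change here can move the number beyond the scatter, whereas a number 0.20 log units lower from compound 1 to compound 3 (within the scatter) does not. The entering group brings both a hydrogen-bond donor and a three-membered non-aromatic ring of carbon only. No available measurement bears on the cause of this step.

Which of these two differences carries the step remains open. Also open, from the compounds shown here alone, is how a 1-carbamoylpropyl group, a carboxylic acid or an amine at this place would read on the core of compound 2.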